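A few compounds are considered here, and "the series" means these few. Any claim that something is new, unique, unknown or untested is made for them only; others in the source may bear on it.

Three compounds sharing one core and differing in a single group, on a saturated chain carbon bound to an aromatic carbon and a saturated chain carbon, have been measured in an ADME assay on microsomes from liver (Mus musculus) for metabolic stability; a higher number here means that the compound lasts longer, a lower number that the compound disappears faster. There, compound 1 `CC(C)C(Nc1nnc[nH]1)c1ccc(-c2ccc3cccc(F)c3c2)[nH]c1=O` gives 2.42 h, compound 2 `CC(C)C(c1ccc(-c2ccc3cccc(F)c3c2)[nH]c1=O)N1CCCCC1=O` gives 0.0967 h, and compound 3 `CC(C)C(c1ccc(-c2ccc3cccc(F)c3c2)[nH]c1=O)N1CCN/C1=N\C#N` gives 0.207 h. Compound 3 therefore holds the middle of the three numbers. The large steps are a 25-fold lower number from compound 1 to compound 2 (1.40 log units; beyond the scatter) and a 12-fold lower number from compound 1 to compound 3 (1.07 log units; beyond the scatter), whereas a 2.1-fold higher number from compound 2 to compound 3 (0.33 log units; beyond the scatter) is modest.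

Compound 4 `CC(C)C(Cc1noc(=O)[nH]1)c1ccc(-c2ccc3cccc(F)c3c2)[nH]c1=O` has not yet been measured. The change is a group of 7 heavy atoms (3 carbon, 2 nitrogen, 2 oxygen; one five-membered aromatic ring with 3 hetero atoms) in place of a group of 8 heavy atoms (4 carbon, 4 nitrogen; one five-membered non-aromatic ring with 2 hetero atoms), on a saturated chain carbon bound to an aromatic carbon and a saturated chain carbon. Among the measured compounds shown here, its incoming group is a five-membered aromatic ring, a feature otherwise seen only in compound 1, while compound 2 and compound 3 carry non-aromatic rings. This comparison rests on a single compound, and the two aromatic groups are not the same, so only part of a 12-fold lower number from compound 1 to compound 3 (1.07 log units; beyond the scatter) is expected to carry over, in the same upward direction. The expected result in this assay is a higher number, a 3.9-fold higher number from compound 3 to compound 4 (0.59 log units; beyond the scatter). Compound 4 is estimated at 0.8 h, with an expected range from 0.2 h to 3 h.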

Compound 4, half-life: 2.78 h
Estimate against measurement, compound 4: 3.5-fold (0.54 log units) below, and the stated range covers the measured number.
By their numbers in this assay, from the lowest: compound 2; then compound 3; then compounds 1 and 4 (each within the scatter of the next).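

In this assay the new result gives a large step of a 13-fold higher number from compound 3 to compound 4 (1.13 log units; beyond the scatter) and another of a 29-fold higher number from compound 2 to compound 4 (1.46 log units; beyond the scatter), so a five-membered aromatic ring with 3 hetero atoms, on a saturated chain carbon bound to an aromatic carbon and a saturated chain carbon, now separates from both non-aromatic rings in more than one example. The step of a 1.1-fold higher number from compound 1 to compound 4 (0.06 log units; within the scatter) lies within the scatter, although the two aromatic groups differ in their atoms, so at this place the read-out does not tell these two groups apart, and none of the four compounds goes against the split between aromatic and non-aromatic rings. Nothing available bears on why the rings divide in this way.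

Four compounds cannot show whether the split depends on the hetero atoms of the ring or on its being aromatic at all, and a plain phenyl ring on the same carbon would separate those two readings. From the compounds shown here alone, it also stays open how an open group such as a carboxylic acid or a primary amine would fall relative to the two sets of rings.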